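Replacing the 4-methoxybenzyl arm of compound 1 with cyclohexylmethyl

This account rests on a few compounds, and the source may have more. Where it says the series, first, only, none or still open, it means among the compounds named here.

Among the compounds with values here, compound 1 `COc1ccc(CN2CCC(C(=O)Nc3cc(Cl)c(N)cc3OC)CC2)cc1` is the only member of the series with a definite number in a functional assay on the whole organism for antagonist activity, with Mus musculus as the target (a lower number here means that less compound is needed, a higher number that more compound is needed for the effect), where compound 1 gives 0.9 mg/kg. Compound 2 `COc1cccc(CN2CCC(C(=O)Nc3cc(Cl)c(N)cc3OC)CC2)c1` reaches only the limit of the assay, > 4 mg/kg. Compound 3 `COc1cc(N)c(Cl)cc1NC(=O)C1CCN(Cc2ccc(OCc3ccccc3)cc2)CC1` likewise stops at a limit, > 4 mg/kg. The result is an at least 4.4-fold higher number from compound 1 to compound 2 (0.64 log units; beyond the scatter) and an at least 4.4-fold higher number from compound 1 to compound 3 (0.64 log units; beyond the scatter); both changes touch the arm carried on the saturated chain carbon bound to the amine nitrogen in the ring, and both push the value to the limit of > 4 mg/kg in this assay, at which 2 of the 3 values shown sit.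

Compound 4 `COc1cc(N)c(Cl)cc1NC(=O)C1CCN(CC2CCCCC2)CC1` differs from compound 1 by cyclohexyl in place of 4-methoxyphenyl on a saturated chain carbon bound to an amine nitrogen in a ring. Both measured steps that alter this arm weaken the compound beyond the scatter, so a step of similar direction is expected here, with a good chance that compound 4 also ends at a limit. In this assay compound 4 is expected to give 4 mg/kg, within 1.5 mg/kg to 12 mg/kg. The expected step is a 4.4-fold higher number from compound 1 to compound 4 (0.65 log units; beyond the scatter).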

Compound 4, dose for half-maximal effect: 2.9 mg/kg
Estimate against measurement, compound 4: 1.4-fold (0.14 log units) above; low and high end bracket the measured number.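

Cyclohexyl in place of 4-methoxyphenyl gives a 3.2-fold higher number from compound 1 to compound 4 (0.51 log units; beyond the scatter) in this assay, so this change on the arm also loses ground. Unlike the other two changes on the arm, it leaves a definite number, and neither the aromatic ring nor the oxygen of compound 1 is required for one. Compound 4 does not join the compounds at the limit: the limit of > 4 mg/kg in this assay, at which 2 of the 4 values shown sit. The value of compound 2 is a limit. The remaining step on this arm is therefore only a floor, and it gives no order between the two compounds: an at least 1.3-fold lower number from compound 2 to compound 4 (0.13 log units; that floor lies within the scatter).

On these data alone, the change removes the methoxy group and the aromatic ring together, so the share of each in the step stays open; a plain phenyl on the same carbon would separate them. As far as these compounds go, whether a longer chain or an amine on this arm is tolerated also stays open.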